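The compounds below may be only part of what the source reports. "The series", "measured", "known", "first", "only" and "open" are said of these compounds alone.

For the measured compounds named here, compound 1, with structure `CCc1nnc(O)n2c(C(C)(C)C)nc(C)c12`, is the only compound in this set for which a functional assay for inhibition, with Homo sapiens as the target (on this read-out lower numbers stand for stronger inhibition and higher numbers for weaker inhibition), returns a definite number: in this assay compound 1 gives 26000 nM. The other measured compound, compound 2 with structure `CC(=O)N(C1=NNCC1)c1nncc2c(C)ncn12`, reaches only a limit of the assay in this assay, where compound 2 gives > 48000 nM. Compound 3, with structure `CCc1nnc(O)n2c(C(C)CC)nc(C)c12`, has not yet been measured. Compound 3 differs from compound 1 in one place: sec-butyl in place of tert-butyl on an aromatic carbon. Going by the values given here, the two have the same atoms joined differently, and no measured pair in this set shows what such a rearrangement does in this assay. The step from compound 1 to compound 3 is expected to stay within the usual scatter of repeated measurements, with the estimated change being a 1.2-fold higher number from compound 1 to compound 3 (0.06 log units; within the scatter). Compound 3 is therefore estimated to give 30000 nM in this assay, within a range from 12000 nM to 75000 nM.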

Compound 3, half-maximal inhibitory concentration: 45000 nM
Beside the measured number, compound 3's estimate is 1.5-fold (0.18 log units) below it, within the range that was stated.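

For the compounds shown here, this is the first pair in the set that differs in one place, and in this assay the step is a 1.7-fold higher number from compound 1 to compound 3 (0.24 log units; within the scatter). At the aromatic carbon between two ring nitrogen atoms, then, sec-butyl and tert-butyl cannot be told apart on this read-out, so rearranging the same atoms within this chain leaves the number within the scatter. This says nothing firmer about the position, and the one limit in the set, which belongs to compound 2, is a limit and not a number: the limit of > 48000 nM in this assay, at which 1 of the 3 values shown sits.

On these data alone, whether an amine, a carboxylic acid or a longer chain such as n-hexyl at this position would move the number beyond the scatter remains open. The compounds shown also leave open whether any change elsewhere on the shared core would do so.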